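From methyl to methoxy: compound 3 to compound 4

The source may hold more compounds than are shown below. What is called first, only, known or untested is meant among the compounds shown, and "the series" means these compounds.

Measured in a functional assay on MCF7 cells (Homo sapiens) for cytotoxicity, read by MTT assay, with a stated time of 68 h; a lower number here means a stronger inhibitor, a higher number a weaker inhibitor:
- compound 1 `O=C(/C=C/c1cccc(OCc2ccccc2)c1)c1ccc(Cl)cc1Cl`: 9400 nM
- compound 2 `COc1cc([C@H]2Oc3cc([C@H]4Oc5ccccc5C(=O)[C@@H]4O)ccc3O[C@@H]2CO)ccc1O`: 13800 nM
- compound 3 `Cc1ccc(C(=O)/C=C/c2cccc(OCc3ccccc3)c2)cc1`: 21700 nM

Compound 3, at 21700 nM, cannot be told apart from compound 2, at 13800 nM, since the two lie within the scatter of each other. Among the compounds with values here, compound 1 stands clearly lower, at 9400 nM, and only this pair is joined by a measured step.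

Compound 4 `COc1ccc(C(=O)/C=C/c2cccc(OCc3ccccc3)c2)cc1` differs from compound 3 in one place: methoxy in place of methyl on an aromatic carbon. This is methoxy in place of methyl on an aromatic carbon, para to a large group, and the same difference can be read as 4-methylphenyl to 4-methoxyphenyl.

Within the data shown here, one measured step bears on this change, and only loosely. It is the modest 2.3-fold higher number from compound 1 to compound 3 (0.36 log units; beyond the scatter), which brought in 4-methylphenyl in place of 2,4-dichlorophenyl. Among the measured compounds shown here, no measured compound carries the methoxy group, so the data give no direct guide to its effect. With compound 3 at 21700 nM as the anchor, no step beyond the scatter is expected in this assay, in either direction.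

The estimated step is a 1.2-fold lower number from compound 3 to compound 4 (0.08 log units; within the scatter). For compound 4 the expected value is 18000 nM, with an estimated range from 8000 nM to 40000 nM.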

Compound 4, half-maximal inhibitory concentration: 6000 nM
The estimate for compound 4 lay 3.0-fold (0.48 log units) above the measured number; measured number below the stated range.
By their numbers in this assay, from the lowest: compounds 4, 1, 2 and 3 (each within the scatter of the next, the first and the last beyond it).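

In this assay, within the data shown here, the aromatic carbon para to a large group proves responsive to the swap of methyl for methoxy: the change gives a 3.6-fold lower number from compound 3 to compound 4 (0.56 log units; beyond the scatter), a step beyond the scatter, and none of the earlier compounds carried methoxy to show this. It also alters how the two aryl ketones compare, since the 4-methylphenyl compound stood apart from the 2,4-dichlorophenyl compound, whereas the 4-methoxyphenyl group gives a 1.6-fold lower number from compound 1 to compound 4 (0.19 log units; within the scatter), which is within the scatter, so compound 4 and compound 1 cannot be told apart in this assay. No measurement in hand accounts for the effect of the methoxy group on this cytotoxicity read-out.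

The compounds shown leave open whether this step belongs to methoxy alone or would extend to a hydroxyl, an ethoxy or a dimethylamino group on the same carbon. They also leave open whether methoxy would keep its effect on the 2,4-dichlorophenyl ring of compound 1, or when moved to another carbon of the ring, and whether the benzyloxy group on the far ring of the shared core could be replaced by a smaller ether without loss.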